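A few compounds are considered here, and "the series" means these few. Any claim that something is new, unique, unknown or untested is made for them only; others in the source may bear on it.

Measured compounds:
- compound 1 `c1ccc2c(c1)CN[C@@H](CN(CCCCNCC1CCOCC1)[C@H]1CCCc3cccnc31)C2` — in a functional assay on cells for agonist activity at C-X-C chemokine receptor type 4 (Homo sapiens), read by fluorescence and calcium flux, with a stated time of 90 s (on this read-out lower numbers stand for an effect already at smaller amounts and higher numbers for an effect only at larger amounts of compound), compound 1 gives > 30000 nM, which is a limit of the assay and not a number.
- compound 2 `CC1(C)CCC(NCCCCN(C[C@H]2Cc3ccccc3CN2)[C@H]2CCCc3cccnc32)CC1` — in this assay compound 2 gives > 30000 nM, again a limit and not a number.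

Compound 1 stands at the limit of this assay, where (the limit of > 30000 nM in this assay, at which 2 of the 2 values shown sit). For the measured compounds named here, the one measured step, a step that the two limits leave unreadable from compound 1 to compound 2, consists of 4,4-dimethylcyclohexyl in place of (oxan-4-yl)methyl on an amine nitrogen, and its size cannot be read, as both ends are limits.

The unmeasured compound 3 `NCc1ccccc1CN(C[C@H]1Cc2ccccc2CN1)[C@H]1CCCc2cccnc21` differs from compound 1 by a group of 8 heavy atoms (7 carbon, 1 nitrogen; one six-membered aromatic ring of carbon only) in place of a group of 11 heavy atoms (9 carbon, 1 nitrogen, 1 oxygen; one six-membered non-aromatic ring with 1 hetero atom), on a saturated chain carbon bound to an amine nitrogen. Going by the values given here, no measured step covers this kind of change; the only step available, from compound 1 to compound 2, touches a different part of the molecule and is itself unreadable. There is therefore no basis for expecting a step of any particular size or direction in this assay, and the most likely outcome is that compound 3 also ends at a limit.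

Compound 3 is expected to give about 25000 nM in this assay, with a plausible range from 3000 nM to 60000 nM; the expected step of an at least 1.2-fold lower number from compound 1 to compound 3 (0.07 log units; that floor lies within the scatter) is accordingly not readable beyond the scatter.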

Compound 3, half-maximal effective concentration: > 30000 nM
Compound 3 ended at the assay's limit; the forecaster's own chance of this, stated with the estimate: 60%; at least 1.2-fold (0.07 log units) between middle value and limit.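

Compound 3 gives > 30000 nM in this assay, which is a limit and not a number. Compound 1 also stands at a limit, so the change from compound 1 to compound 3 cannot be read as a step of any size: the limit of > 30000 nM in this assay, at which 3 of the 3 values shown sit. The compounds shown leave open which structure, if any, would give a readable number in this assay.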